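A few compounds are considered here, and "the series" means these few. Any claim that something is new, unique, unknown or untested is made for them only; others in the source may bear on it.

Among the measured compounds shown here, compound 2 `O=C1O[C@H]([C@@H](O)Cn2cc(CNS(=O)(=O)c3ccc(F)cc3)nn2)C(OCc2ccccc2)=C1OCc1ccccc1` is the one member of the series with a number rather than a limit in an ADME assay on HFF cells (Homo sapiens) for cytotoxicity, read by MTT assay, with a stated time of 72 h (on this read-out lower numbers stand for stronger inhibition and higher numbers for weaker inhibition), where compound 2 gives 30 nM. Compound 1 `Cc1ccc(-c2cn(C/C=C3\OC(=O)C(OCc4ccccc4)=C3OCc3ccccc3)nn2)cc1` returns only a limit of the assay, > 100000 nM. Compound 3 `CCCCCc1ccc(-c2cn(C/C=C3\OC(=O)C(OCc4ccccc4)=C3OCc3ccccc3)nn2)cc1` likewise returns a limit, > 100000 nM. For the measured compounds named here, the single recorded step, a step that the two limits leave unreadable from compound 1 to compound 3, puts butyl in place of hydrogen on a saturated chain carbon bound to an aromatic carbon, and both of its ends sit at the limit of > 100000 nM in this assay, at which 2 of the 3 values shown sit, so it gives no usable size. Compound 4 `CCCCCCCCCCc1cn(C[C@H](O)[C@H]2OC(=O)C(OCc3ccccc3)=C2OCc2ccccc2)nn1` differs from compound 2 in one place: nonyl in place of ((4-fluorophenyl)sulfonyl)amino on a saturated chain carbon bound to an aromatic carbon. Going by the values given here, no measured step carries this change, and the one step on record, though it also grows a chain on a saturated chain carbon bound to an aromatic carbon, cannot be read. Compound 2 alone anchors the estimate. A moderate weakening is expected for compound 4, the estimated step being a 10-fold higher number from compound 2 to compound 4 (1.00 log units; beyond the scatter). Compound 4 is therefore expected to give about 300 nM, within a range from 30 nM to 3000 nM.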

Compound 4, half-maximal inhibitory concentration: > 100000 nM
Compound 4: only a limit was reported (the forecaster's own chance of this, stated with the estimate: 20%); at least 330-fold (2.52 log units) between middle value and limit.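

In this assay, among the compounds shown here, nonyl in place of ((4-fluorophenyl)sulfonyl)amino on a saturated chain carbon bound to an aromatic carbon gives an at least 3300-fold higher number from compound 2 to compound 4 (3.52 log units; beyond the scatter), the first readable step, and it shows that the number of compound 2 does not survive this change. The value of compound 4, > 100000 nM, is a limit, so the step has a lower bound and no full size. The step between compound 1 and compound 3 cannot be read, and compound 2 remains the only member with a number: the limit of > 100000 nM in this assay, at which 3 of the 4 values shown sit.

Open, as far as these compounds go, is whether an amine, a carboxylic acid or a chain shorter than nonyl at this place would give a number or a limit. Also open, from the compounds shown here alone, is which part of ((4-fluorophenyl)sulfonyl)amino matters, for instance whether (phenylsulfonyl)amino without the fluorine would match it.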